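The source may report more compounds than this note shows. Statements on the series, on what has been measured and on what is new or still open speak of the compounds shown alone.

Measured so far in a physicochemical assay for lipophilicity, at pH 7.4; a higher number here means a more lipophilic compound, a lower number a more polar compound:
- compound 1 `CCc1ccc(N(CC(C)C)S(=O)(=O)c2ccc3c(c2)C(O)CC(C2CCN(S(C)(=O)=O)CC2)O3)cc1`: 3.22
- compound 2 `CC(C)CN(c1cccc(F)c1)S(=O)(=O)c1ccc2c(c1)C(O)CC(C1CCOCC1)O2`: 3.39
- compound 3 `CC(C)CN(c1ccccc1C(F)(F)F)S(=O)(=O)c1ccc2c(c1)C(O)CC(C1CCOCC1)O2`: 4.14

In this assay, compound 1 at 3.22 and compound 2 at 3.39 lie within the scatter of each other. Compound 3 at 4.14 stands beyond the scatter above both of them.

The next compound to be measured is compound 4 `CCc1ccc(N(CC(C)C)S(=O)(=O)c2ccc3c(c2)C(O)CC(C2CCN(C)CC2)O3)cc1`. It differs from compound 1 in one place, with methyl in place of methylsulfonyl on an amine nitrogen in a ring. In full, 1-(methylsulfonyl)piperidin-4-yl becomes 1-methylpiperidin-4-yl.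

Among the compounds with values here, only one measured step changes a single place, and that is a number 0.75 log units higher from compound 2 to compound 3 (beyond the scatter), with 2-(trifluoromethyl)phenyl in place of 3-fluorophenyl on a sulfonamide nitrogen. This step lies at a different place in the molecule, so it bears on the new change only loosely. It shows how large one change can be among these compounds, but it gives no direction. Within the data shown here, no measured pair alters the group on the ring nitrogen, so the direction here is a judgement from the structural change alone, and a small drop seems the likelier outcome.

Among the measured compounds shown here, the expected change is estimated as a number 0.32 log units lower from compound 1 to compound 4 (beyond the scatter), smaller than the one measured step. Compound 4 is therefore expected at 2.9, within an estimated range of 2.2 to 3.6.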

Compound 4, distribution coefficient: 2.67
Beside the measured number, compound 4's estimate is 0.23 log units above it, and the stated range covers the measured number.
By their numbers in this assay, from the lowest: compound 4; then compounds 1 and 2 (each within the scatter of the next); then compound 3.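

In this assay, the group on the amine nitrogen of the six-membered non-aromatic ring can move the number on its own: with methyl in place of methylsulfonyl, the result is a number 0.55 log units lower from compound 1 to compound 4 (beyond the scatter) for this single change. Within the data shown here, the earlier compounds left the direction of this change unsettled, and this pair is the first to show it, with a group of 4 heavy atoms and 2 hydrogen-bond acceptors giving way to a group of 1 heavy atom and no hydrogen-bond acceptors. No measurement available here accounts for the direction or size of this step.

From the compounds shown here alone, what an acetyl group, a bare hydrogen or a longer chain such as propyl would do on that same nitrogen remains open, and so does whether the number tracks the size of the group or depends on the sulfonyl unit itself. Among these compounds, this one pair is also the only reading at this position, so it remains open whether the same swap would give a similar step with a different group on the sulfonamide nitrogen.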